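The compounds below may be only part of what the source reports. "The series", "measured", "known", "first", "only" and "open" are said of these compounds alone.

Of the compounds shown here, three sharing one core have been tested in a functional assay on MCF7 cells (Homo sapiens) for cytotoxicity, read by MTT assay; on this read-out lower numbers stand for stronger inhibition and higher numbers for weaker inhibition. Compound 1 `c1ccc(-c2nnc(-c3c[nH]c4ccccc34)o2)cc1` gives 388000 nM. Compound 3 `Clc1ccc(-c2nnc(-c3c[nH]c4ccccc34)o2)cc1` gives 48200 nM. Compound 2 `COc1ccc(-c2nnc(-c3c[nH]c4ccccc34)o2)cc1` reaches only a limit in this assay, > 1000000 nM. Compound 2 thus stands at the weak end of the three, sitting at the limit of > 1000000 nM in this assay, at which 1 of the 3 values shown sits. Compound 4 `COc1ccc(-c2nnc(-c3c[nH]c4ccccc34)o2)cc1OC` differs from compound 2 by methoxy in place of hydrogen on an aromatic carbon. Within the data shown here, the one step that bears on this change is an at least 2.5-fold higher number from compound 1 to compound 2 (0.41 log units; beyond the scatter), a weakening of at least modest size; an 8.0-fold lower number from compound 1 to compound 3 (0.91 log units; beyond the scatter) and an at least 20-fold lower number from compound 2 to compound 3 (1.31 log units; beyond the scatter) run the other way but concern chloro, not methoxy. A second methoxy is therefore expected to keep the number at or beyond the limit. For compound 4 the estimated step is a step that the limit leaves unreadable from compound 2 to compound 4. Compound 4 is expected near 1500000 nM, between 500000 nM and 5000000 nM.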

Compound 4, half-maximal inhibitory concentration: 557000 nM
Compound 4: the middle estimate sits 2.7-fold (0.43 log units) above what was measured, within the range that was stated.
By their numbers in this assay, from the lowest: compound 3; then compounds 1 and 4 (each within the scatter of the next). At a limit, above all of these: compound 2.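

In this assay, methoxy in place of hydrogen, ortho to a methoxy group and meta to a large group, gives an at least 1.7-fold lower number from compound 2 to compound 4 (0.25 log units; that floor lies within the scatter). Compound 2 has only a limit, > 1000000 nM. So a methoxy at this place does not carry the number past that limit as the first methoxy did: compound 4 has a measured value, though the true size of this step remains unknown. What the compounds shown leave open is whether chloro, an amine or a carboxylic acid at this same place, ortho to the methoxy group, would give a lower number.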